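Rearranging one ring pair in the shared core

The source may report more compounds than this note shows. Statements on the series, on what has been measured and on what is new or still open speak of the compounds shown alone.

Of the compounds shown here, two have been measured in a functional assay on A549 cells (Homo sapiens) for cytotoxicity, read by MTT assay, with a stated time of 72 h; a lower number here means a stronger inhibitor, a higher number a weaker inhibitor. Compound 1 `Cc1cc(=O)n(-c2ccccc2OC(F)(F)F)nc1C(=O)Nc1ccc(Oc2ncnc3ccsc23)c(F)c1` gives 5720 nM. Compound 2 `Cc1cc(=O)n(-c2cccc(F)c2)nc1C(=O)Nc1ccc(Oc2ncnc3ccsc23)c(F)c1` gives 5220 nM. Going by the values given here, the only step between them, a 1.1-fold lower number from compound 1 to compound 2 (0.04 log units; within the scatter), is small and tells little about any other change. Among these two numbers compound 2 stands lowest, though its gap to compound 1 is within the scatter, so the two cannot be ranked.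

Compound 3 `Cc1cc(=O)n(-c2cccc(F)c2)nc1C(=O)Nc1ccc(Oc2ncnc3sccc23)c(F)c1` keeps everything in compound 2 except one part: a group of 9 heavy atoms (6 carbon, 2 nitrogen, 1 sulfur; one five-membered aromatic ring with 1 hetero atom, one six-membered aromatic ring with 2 hetero atoms) in place of a group of 9 heavy atoms (6 carbon, 2 nitrogen, 1 sulfur; one five-membered aromatic ring with 1 hetero atom, one six-membered aromatic ring with 2 hetero atoms), on an oxygen on an aromatic ring. The two compounds have the same atoms, joined differently, so this is a rearrangement of the group on the oxygen rather than an exchange of one group for another. Among the compounds with values here, no measured step touches this position; the single step available concerns a group on an aromatic nitrogen at the other end of the molecule and therefore does not bear on it.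

With nothing to guide a shift either way, the expected change from compound 2 to compound 3 in this assay is a 1.0-fold lower number from compound 2 to compound 3 (0.00 log units; within the scatter), a step that is not expected to exceed the scatter. Compound 3 is therefore estimated at 5200 nM, within a range from 1800 nM to 15000 nM.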

Compound 3, half-maximal inhibitory concentration: 19500 nM
Compound 3: middle estimate off by 3.8-fold (0.57 log units), on the low side, and the stated range ends below it.
By their numbers in this assay, from the lowest: compounds 2 and 1 (each within the scatter of the next); then compound 3.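

The same atoms joined differently on the oxygen on an aromatic ring are enough to shift the result in this assay, with a 3.7-fold higher number from compound 2 to compound 3 (0.57 log units; beyond the scatter). Going by these compounds alone, the earlier step, a 1.1-fold lower number from compound 1 to compound 2 (0.04 log units; within the scatter), concerned only the group on an aromatic nitrogen and stayed within the scatter, so this pair gives the first change beyond the scatter, though a modest one, and it comes from the other end of the molecule. The counted features of the leaving and entering groups are identical, so those counts do not separate compound 2 from compound 3, and no measurement is available to explain the difference.

This single pair leaves open whether the same rearrangement would shift the number similarly with a 2-(trifluoromethoxy)phenyl group on the aromatic nitrogen, as in compound 1, instead of the 3-fluorophenyl group. It also leaves open how the number would respond if the group on the oxygen carried an added amine or a carboxylic acid, or if a plain phenyl ring took its place.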